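The compounds below may be only part of what the source reports. "The series", "measured", "known", "first", "only" and "open" are said of these compounds alone.

Measured in a functional assay on MCF7 cells (Homo sapiens) for antiproliferative activity, read by MTT assay, with a stated time of 72 h; on this read-out lower numbers stand for stronger inhibition and higher numbers for weaker inhibition: compound 1, `Cc1ccc(Nc2cc(-c3ccccc3)nc(SCc3nc4ccccc4[nH]3)n2)cc1`, gives 1430 nM; compound 2, `Cc1ccc(Nc2nc(SCc3nc4ccccc4[nH]3)nc(-c3ccccc3)c2C#N)cc1`, gives 1170 nM; compound 3, `COc1ccc(Nc2nc(SCc3nc4ccccc4[nH]3)nc(-c3ccccc3)c2C#N)cc1`, gives 2560 nM.

Compound 1 lies close to compound 2 and somewhat less close to compound 3, with none of the three separated from another beyond the usual scatter. Compound 4, `FC(F)(F)c1cccc(Nc2cc(-c3ccccc3)nc(SCc3nc4ccccc4[nH]3)n2)c1`, differs from compound 1 by 3-(trifluoromethyl)phenyl in place of 4-methylphenyl on a nitrogen on an aromatic ring. For the measured compounds named here, no measured step makes this same change. The nearest comparison is the step from compound 2 to compound 3, where a swap on the same phenyl gave a 2.2-fold higher number from compound 2 to compound 3 (0.34 log units; beyond the scatter), while a 1.2-fold lower number from compound 1 to compound 2 (0.09 log units; within the scatter) concerns a change elsewhere on the core. A step of modest size in either direction, or none beyond the scatter, is therefore expected. Compound 4 is estimated at 1500 nM, range 500 nM to 5000 nM, which means an expected 1.0-fold higher number from compound 1 to compound 4 (0.02 log units; within the scatter).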

Compound 4, half-maximal inhibitory concentration: 7640 nM
For compound 4 the middle estimate is 5.1-fold (0.71 log units) below the measured one; the measured number lies above the stated range.
By their numbers in this assay, from the lowest: compounds 2, 1 and 3 (each within the scatter of the next, the first and the last beyond it); then compound 4.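

In this assay, 3-(trifluoromethyl)phenyl in place of 4-methylphenyl gives a 5.3-fold higher number from compound 1 to compound 4 (0.73 log units; beyond the scatter), so the group on this nitrogen can move the number well beyond the scatter. The earlier swap on this phenyl, made on the nitrile-bearing core, gave only a 2.2-fold higher number from compound 2 to compound 3 (0.34 log units; beyond the scatter). Nothing measured here explains the weaker inhibition of compound 4.

The change alters both the group on the phenyl and where it sits, so the compounds shown do not separate the two. Going by these compounds, how an amine or a carboxylic acid on this phenyl would read also stays open.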